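Aryl esters on the shared core: stepping from nitro to methyl

A few compounds are considered here, and "the series" means these few. Any claim that something is new, unique, unknown or untested is made for them only; others in the source may bear on it.

The series pairs two cores with benzoate esters. Compound 1 `Cc1cc2c(C(C)C)ccc(C)c2cc1OC(=O)c1cccc(C(F)(F)F)c1` carries a 3-trifluoromethylphenyl ester and in a functional assay on U-251 cells (Homo sapiens) for antiproliferative activity, read by sulforhodamine B assay, with a stated time of 48 h, tested at 50 uM (a higher number here means more inhibition at the concentration tested (going by the name of the read-out), a lower number less inhibition), compound 1 is reported as "not active" (no number reported), without a number. Compound 3 `Cc1cc2c(C(C)C)ccc(C)c2cc1OC(=O)c1ccc(C(F)(F)F)cc1`, the 4-trifluoromethyl isomer on the same core, gives 16.5% in this assay. Compound 2 `CC1=CC[C@H](C(C)C)c2cc(C)c(OC(=O)c3ccc([N+](=O)[O-])cc3)cc21`, on the partly saturated core with a 4-nitrophenyl ester, gives 16.8% in this assay. Compound 2 and compound 3 sit within the scatter of each other, so no order between them can be read, and compound 2 stands simply as one of the two reported numbers, with compound 1 giving no figure to compare.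

Compound 4 `CC1=CC[C@H](C(C)C)c2cc(C)c(OC(=O)c3cccc(C)c3)cc21` keeps the core of compound 2 and alters only the ester aryl group: 3-methylphenyl in place of 4-nitrophenyl on a carbonyl carbon. Within the data shown here, no step between two measured compounds is available for this change. Both reported numbers lie in a narrow band regardless of the aryl substituent, so the expectation for the step from compound 2 to compound 4 is that it stays within the scatter, a number 2.8 percentage points lower from compound 2 to compound 4 (within the scatter), with no direction called. On that basis compound 4 is estimated at 14% in this assay, with a range from 3% to 26%.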

Compound 4, a percentage reported as inhibition, at one concentration (the size of the read-out at that concentration, not a potency): 16.8%
For compound 4 the middle estimate is 2.8 percentage points below the measured one; the range from low to high includes it.
By their numbers in this assay, from the lowest: compounds 3, 2 and 4 (each within the scatter of the next).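

Among these compounds, this is the first step between two measured compounds at this place: on the core of compound 2, 3-methylphenyl in place of 4-nitrophenyl on a carbonyl carbon gives no change at the digits printed from compound 2 to compound 4 (within the scatter) in this assay. The swap exchanges a group with 2 hydrogen-bond acceptors and nitrogen and oxygen atoms for an all-carbon group with 0 hydrogen-bond acceptors, and the read-out at the single concentration tested does not separate the two, so on this core neither the nitro group nor its replacement by methyl registers here. The identity of the substituent and its place on the aryl ring changed together in this step, so the two contributions cannot be told apart, and nothing in the data on hand accounts for the flat result.

On these data alone, it remains open whether an amine or a carboxylic acid on the aryl ring, or a longer chain in place of the ring, would move the number beyond the scatter. As far as these compounds go, it is also open whether the same swap on the core of compound 3 would behave alike, and a single-concentration percentage gives no potency for any of these esters.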